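The source may hold more compounds than are shown below. What is called first, only, known or untested is meant among the compounds shown, and "the series" means these compounds.

In a functional assay on MCF7 cells (Homo sapiens) for inhibition, read by CCK-8 assay, with a stated time of 48 h (a lower number here means a stronger inhibitor, a higher number a weaker inhibitor), compound 1 `COc1cc(-c2ccnc3cc(-c4ccc(C(C)=O)cc4)nn23)cc(OC)c1OC` gives 5230 nM; compound 2 `COc1ccc(-c2cc3nccc(-c4cc(OC)c(OC)c(OC)c4)n3n2)cc1F` gives 183 nM; compound 3 `COc1cc(-c2ccnc3cc(-c4ccc(N(C)C)cc4)nn23)cc(OC)c1OC` gives 44 nM.

Compound 3 has the lowest number of the three, with compound 2 nearest at a 4.2-fold lower number from compound 2 to compound 3 (0.62 log units; beyond the scatter) and compound 1 furthest at a 120-fold lower number from compound 1 to compound 3 (2.08 log units; beyond the scatter). Compound 4 `COc1cc(-c2ccnc3cc(-c4cn(C)c5ccccc45)nn23)cc(OC)c1OC` differs from compound 3 in one place: 1-methyl-1H-indol-3-yl in place of 4-(dimethylamino)phenyl on an aromatic carbon. Every measured step changed the group at this same position, and each lay beyond the scatter: a 29-fold lower number from compound 1 to compound 2 (1.46 log units; beyond the scatter), a 120-fold lower number from compound 1 to compound 3 (2.08 log units; beyond the scatter) and a 4.2-fold lower number from compound 2 to compound 3 (0.62 log units; beyond the scatter). None of those steps brought in a group with two rings, so the record gives no direct guide. For compound 4 a modest rise in the number is expected, a 2.5-fold higher number from compound 3 to compound 4 (0.40 log units; beyond the scatter), and its value in this assay is estimated at 110 nM, within 25 nM to 500 nM.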

Compound 4, half-maximal inhibitory concentration: 95 nM
For compound 4 the middle estimate is 1.2-fold (0.06 log units) above the measured one; low and high end bracket the measured number.
By their numbers in this assay, from the lowest: compound 3; then compounds 4 and 2 (each within the scatter of the next); then compound 1.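

For the compounds shown here, the position accepts a group with two rings, which no earlier compound carried: 1-methyl-1H-indol-3-yl gives only a modest rise against 4-(dimethylamino)phenyl (a 2.2-fold higher number from compound 3 to compound 4 (0.33 log units; beyond the scatter)) and a large drop against 4-acetylphenyl (a 55-fold lower number from compound 1 to compound 4 (1.74 log units; beyond the scatter)). Against 3-fluoro-4-methoxyphenyl (a 1.9-fold lower number from compound 2 to compound 4 (0.28 log units; within the scatter)) the step stays within the scatter, so these two groups cannot be told apart here. The compounds shown leave open how a morpholine or a carboxylic acid on the phenyl ring would fare at this position, and nothing measured here accounts for these steps.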